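Swapping the five-membered ring on compound 2

This account rests on a few compounds, and the source may have more. Where it says the series, first, only, none or still open, it means among the compounds named here.

Compound 2 `c1c[nH]c(-c2ccccc2OCC2=NCCN2)c1` gives the lowest of the two numbers in a functional assay for activation of Alpha-1A adrenergic receptor (Homo sapiens), read by calcium flux (a higher number here means that more compound is needed for the effect, a lower number that less compound is needed), at 1.26 nM. Its neighbour compound 1 `c1ccc(-c2cnccn2)c(OCC2=NCCN2)c1` gives 2.51 nM, and the step of a 2.0-fold lower number from compound 1 to compound 2 (0.30 log units; within the scatter) stays within the scatter. Compound 3 `Cc1cnsc1-c1ccccc1OCC1=NCCN1` carries the change (4-methyl-1,2-thiazol-5-yl in place of 1H-pyrrol-2-yl on an aromatic carbon). Among the measured compounds shown here, the only step seen so far, that from compound 1 to compound 2, exchanged one five-membered ring for another without moving the number beyond the scatter, so no large step is expected here either. Compound 3 is expected at 2.5 nM, between 0.6 nM and 10 nM, which means an expected step of a 2.0-fold higher number from compound 2 to compound 3 (0.30 log units; within the scatter).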

Compound 3, half-maximal effective concentration: 12.6 nM
The estimate for compound 3 lay 5.0-fold (0.70 log units) below the measured number; the whole stated range lies below it.
By their numbers in this assay, from the lowest: compounds 2 and 1 (each within the scatter of the next); then compound 3.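

In this assay, 4-methyl-1,2-thiazol-5-yl gives a 10-fold higher number from compound 2 to compound 3 (1.00 log units; beyond the scatter) and also a 5.0-fold higher number from compound 1 to compound 3 (0.70 log units; beyond the scatter), so both steps lie beyond the scatter, unlike the exchange of pyrazin-2-yl for 1H-pyrrol-2-yl. The group on this aromatic carbon can therefore move the number, though only modestly. Nothing available explains this rise.

4-methyl-1,2-thiazol-5-yl brings its methyl and its ring in a single change, so which of the two goes with the higher number stays open. As far as these compounds go, how an amine or a carboxylic acid would read at this place also stays open.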